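The source may report more compounds than this note shows. Statements on the series, on what has been measured and on what is new or still open speak of the compounds shown alone.

Measured so far:
Compound 1, `COc1cc2c(cc1OC)CN(c1ccc(C=O)cc1)CC2`, gives 1550 nM in an assay on isolated protein for inhibition of Amine oxidase [flavin-containing] B (Homo sapiens), with a stated time of 1 h; a lower number here means a stronger inhibitor, a higher number a weaker inhibitor.
Compound 2, `COc1cc2c(cc1OC)CN(c1cc(F)cc(F)c1)CC2`, gives 5100 nM in this assay.

Among the compounds with values here, compound 1 stands lowest of the two numbers so far; compound 2 is the nearest, with a higher number that lies beyond the usual scatter. Compound 3, `COc1cc2c(cc1OC)CN(c1ccc(F)cc1)CC2`, is not yet measured. It differs from compound 1 in one place: fluoro in place of formyl on an aromatic carbon. Within the data shown here, no step between two measured compounds matches this change, so the expectation rests on the two values alone. Because compound 2, which also carries fluoro on its aromatic ring, gives 5100 nM, a move toward a higher number is expected, and the change estimated for compound 3 relative to its parent is a 2.6-fold higher number from compound 1 to compound 3 (0.41 log units; beyond the scatter), beyond the scatter. Compound 3 is therefore expected to give about 4000 nM in this assay, within a range from 1200 nM to 13000 nM.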

Compound 3, half-maximal inhibitory concentration in the Amine oxidase [flavin-containing] B assay: 13500 nM
Estimate against measurement, compound 3: 3.4-fold (0.53 log units) below; the measured number lies above the stated range.
By their numbers in the Amine oxidase [flavin-containing] B assay, from the lowest: compound 1; then compound 2; then compound 3.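

Within the data shown here, the first step at a single place shows that, in the Amine oxidase [flavin-containing] B assay, this position is sensitive to the group it carries: fluoro in place of formyl, on an aromatic carbon para to a large group, gives an 8.7-fold higher number from compound 1 to compound 3 (0.94 log units; beyond the scatter). The change also removes the one hydrogen-bond acceptor that formyl brings, although one pair cannot tie the step to that count. The weaker inhibition comes with higher lipophilicity in a physicochemical assay for lipophilicity, at pH 7.4; on this read-out lower numbers stand for lower lipophilicity and higher numbers for higher lipophilicity: the measured distribution coefficient of compound 1, 3.7, and of compound 3, 4.5, a number 0.80 log units higher (beyond the scatter) In the physicochemical assay compound 1 gives 3.7 and compound 3 gives 4.5.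

With only this pair, the compounds shown leave open whether the step follows the hydrogen-bond acceptor, the distribution coefficient or neither. They also leave open how a nitrile, an amide or a carboxylic acid at this place would read in the Amine oxidase [flavin-containing] B assay, and whether any of these would match formyl there.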